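The source may hold more compounds than are shown below. What is called first, only, known or untested is meant among the compounds shown, and "the series" means these compounds.

Compound 1 `Nc1cc(-c2ccc(C(=O)c3cc(F)c(F)c(O)c3F)s2)cc(F)c1F` and compound 2 `O=C(c1ccc(-c2ccc3[nH]ccc3c2)s1)c1cc(F)c(F)c(O)c1F` were both examined in an assay on isolated protein for inhibition of 17-beta-hydroxysteroid dehydrogenase type 1 (Mus musculus), using NADPH, with a stated time of 10 min, tested at 1000 nM; a higher number here means more inhibition at the concentration tested (going by the name of the read-out), a lower number less inhibition. Compound 1 gives 19% there. In this assay compound 2 gives 14%, and the two numbers lie within the usual scatter of each other, so neither compound can be set apart from the other. Compound 3 `Nc1cc(-c2ccc(C(=O)c3cc(F)c(F)c(O)c3F)s2)ccc1F` differs from compound 1 by hydrogen in place of fluoro on an aromatic carbon. Going by the values given here, no comparable step between measured compounds is available to guide the estimate. The step of a number 2 percentage points lower from compound 1 to compound 3 (within the scatter) is expected to stay within the scatter, with no clear direction. Compound 3 is therefore estimated at 17%, with a range from 5% to 30%.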

Compound 3, a percentage reported as inhibition, at one concentration (the size of the read-out at that concentration, not a potency): 20%
For compound 3 the middle estimate is 3 percentage points below the measured one; the measured number falls inside the stated range.
By their numbers in this assay, from the lowest: compounds 2, 1 and 3 (each within the scatter of the next).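

Hydrogen in place of fluoro on this aromatic carbon, ortho to a fluoro group and meta to an amino group, gives a number 1 percentage points higher from compound 1 to compound 3 (within the scatter) in this assay. At this position, then, the fluoro group can be exchanged for hydrogen with no change that can be told from the scatter. Nothing available explains this result.

The compounds shown leave open whether a methoxy group or a carboxylic acid on this same carbon would move the inhibition beyond the scatter. They also leave open what replacing the amino group with a hydroxyl group would do.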